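The source may report more compounds than this note shows. Statements on the series, on what has been measured and on what is new or still open speak of the compounds shown alone.

Measured so far in an assay on isolated protein for inhibition of Indoleamine 2,3-dioxygenase 1 (Homo sapiens), read by spectrophotometry, with a stated time of 1 h; on this read-out higher numbers stand for weaker inhibition and lower numbers for stronger inhibition:

- Compound 1, `O=[N+]([O-])c1ccc(N/C(=N\O)c2ccc(Cl)cc2)c2nonc12`: 113 nM
- Compound 2, `O=[N+]([O-])c1ccc(N/C(=N\O)c2ccc(F)c(Cl)c2)c2nonc12`: 158 nM

Within the data shown here, compound 2 sits at the same level as the only other measured compound: the step of a 1.4-fold higher number from compound 1 to compound 2 (0.15 log units; within the scatter) lies within the scatter, so the two cannot be told apart on these numbers.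

Compound 3, `O=[N+]([O-])c1ccc(N/C(=N\O)c2ccc(F)c(Br)c2)c2nonc12`, is not yet measured. It differs from compound 2 by bromo in place of chloro on an aromatic carbon. Among the measured compounds shown here, only one measured step bears on this: the move from compound 1 to compound 2 also changed the halogen pattern on that ring, and it stayed within the scatter, as a 1.4-fold higher number from compound 1 to compound 2 (0.15 log units; within the scatter) shows. On that basis no step beyond the scatter is expected from compound 2 to compound 3; the expected step is a 1.1-fold lower number from compound 2 to compound 3 (0.02 log units; within the scatter). The estimate for compound 3 in this assay is 150 nM, with a range from 75 nM to 300 nM.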

Compound 3, half-maximal inhibitory concentration: 92 nM
Beside the measured number, compound 3's estimate is 1.6-fold (0.21 log units) above it; the range from low to high includes it.
By their numbers in this assay, from the lowest: compounds 3, 1 and 2 (each within the scatter of the next).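

In this assay, bromo in place of chloro on this aromatic carbon, ortho to a fluoro group, gives a 1.7-fold lower number from compound 2 to compound 3 (0.23 log units; within the scatter), so on these numbers the two halogens cannot be told apart at this position. The wider change, 3-bromo-4-fluorophenyl in place of 4-chlorophenyl, gives a 1.2-fold lower number from compound 1 to compound 3 (0.09 log units; within the scatter), which means that all three halogen patterns on this ring now sit at one level. Nothing available explains why chloro and bromo read alike here.

From the compounds shown here alone, the ring carries only halogens in these compounds, so it remains open whether a methyl, a methoxy or an amine at this position would keep that level or shift the number beyond the scatter. Also open, going by these compounds, is how a change to the shared core would read in this assay.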